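From compound 2 to compound 3: working notes

A few compounds are considered here, and "the series" means these few. Any claim that something is new, unique, unknown or untested is made for them only; others in the source may bear on it.

Of the compounds shown here, two have been measured in a functional assay on Vero cells (Chlorocebus sabaeus) for cytotoxicity; on this read-out higher numbers stand for lower toxicity in this test and lower numbers for higher toxicity in this test. Compound 1 (`O=c1[nH]c(=O)n(CC(CO)C2CC2O)cc1/C=C/Br`) gives > 500 ug/mL, which is a limit of the assay and not a number. Compound 2 (`O=c1ccn(CC2(CO)CC2CO)c(=O)[nH]1`) gives > 500 ug/mL, also a limit of the assay and not a number. Compound 2 thus stands at the limit of > 500 ug/mL in this assay, at which 2 of the 2 values shown sit.

The next compound is compound 3 (`O=c1[nH]c(=O)n(CC2(CO)CC2CO)cc1/C=C/I`), which differs from compound 2 by one change: 2-iodoethenyl in place of hydrogen on an aromatic carbon. A 2-iodoethenyl replaces hydrogen on an aromatic carbon of the shared core. Among the compounds with values here, no step between measured compounds is available to size this change in this assay, so the expectation is loose. The likeliest outcome is no step beyond the scatter, with compound 3 again reported as a limit. A measurable number would mean a move towards higher toxicity in this test. The estimated step is an at least 1.2-fold lower number from compound 2 to compound 3 (0.09 log units; that floor lies within the scatter). For compound 3 the expected value is 400 ug/mL, with an estimated range from 100 ug/mL to 1000 ug/mL.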

Compound 3, half-maximal cytotoxic concentration: 330 ug/mL
Compound 3: the middle estimate sits 1.2-fold (0.08 log units) above what was measured; low and high end bracket the measured number.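

Within the data shown here, on the aromatic carbon two atoms from the ring nitrogen, 2-iodoethenyl in place of hydrogen gives a number rather than a limit in this assay, and the change reads as an at least 1.5-fold lower number from compound 2 to compound 3 (0.18 log units; that floor lies within the scatter), which is the first sized step. As far as these compounds go, since the value of compound 2 is a limit of the assay and not a number, this step is known only by its floor, so the true size of the change stays unknown and the floor alone does not establish a move beyond the scatter. Compound 3 therefore shows that this position can carry 2-iodoethenyl and still give a measurable read-out, while most of the series shown remains unsized: the limit of > 500 ug/mL in this assay, at which 2 of the 3 values shown sit.

The compounds shown leave open whether a number appears with a smaller group on the same aromatic carbon, such as methyl or ethyl, or only with a 2-iodoethenyl. They also leave open how an amine or a carboxylic acid at this position would read, and whether the read-out of compound 3 would shift with a longer chain there.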